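The source may hold more compounds than are shown below. What is called first, only, known or untested is meant among the compounds shown, and "the series" means these compounds.

Measured so far in a functional assay on A549 cells (Homo sapiens) for inhibition, read by colorimetric assay and MTT assay, with a stated time of 72 h; on this read-out lower numbers stand for stronger inhibition and higher numbers for weaker inhibition:
- Compound 1 `C=CCCCCOc1ccccc1-c1cnc(OCCCCC=C)n1C` gives 7000 nM
- Compound 2 `CCCCOc1ncc(-c2ccccc2OC)n1C` gives 87000 nM
- Compound 3 `CCCCCCOc1ncc(-c2ccccc2OC)n1C` gives 37000 nM

Among these three numbers, compound 3 stands second highest, lower than compound 2 and higher than compound 1.

Compound 4 `C#CCCCCOc1ncc(-c2ccccc2OC)n1C` has not yet been measured. It differs from compound 3 only at the end of the chain, with ethynyl in place of ethyl on a saturated chain carbon, four bonds along the chain from an oxygen on an aromatic ring.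

One measured step involves that same carbon. Putting ethyl in place of hydrogen there gave a 2.4-fold lower number from compound 2 to compound 3 (0.37 log units; beyond the scatter) and that change is modest. Within the data shown here, no measured pair swaps ethyl for ethynyl, and compound 1 differs from compound 3 in more than one place, so the guidance is thin. With only a modest step to go on, no shift beyond the scatter is expected in this assay.

The expected step is a 1.1-fold lower number from compound 3 to compound 4 (0.02 log units; within the scatter) and its direction is uncertain. Compound 4 is estimated at 35000 nM (expected range 14000 nM to 90000 nM).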

Compound 4, half-maximal inhibitory concentration: 22000 nM
For compound 4 the middle estimate is 1.6-fold (0.20 log units) above the measured one, within the range that was stated.
By their numbers in this assay, from the lowest: compound 1; then compounds 4 and 3 (each within the scatter of the next); then compound 2.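

In this assay, ethynyl in place of ethyl at the end of the chain gives a 1.7-fold lower number from compound 3 to compound 4 (0.23 log units; within the scatter) and so cannot be told apart from repeated measurement of a single compound; at this carbon, the triple bond is tolerated without a clear loss or gain. Set against hydrogen on the same carbon, ethynyl gives a 4.0-fold lower number from compound 2 to compound 4 (0.60 log units; beyond the scatter) and ethyl gives a 2.4-fold lower number from compound 2 to compound 3 (0.37 log units; beyond the scatter), so both of these two-carbon ends go with lower numbers than the shorter chain of compound 2. Nothing measured here explains these numbers.

The compounds shown leave open whether a longer chain at this carbon would lower the number further. They also do not show how an amine or a carboxylic acid at the end of the chain would compare.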